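A few compounds are considered here, and "the series" means these few. Any claim that something is new, unique, unknown or untested is made for them only; others in the source may bear on it.

Compound 1 `O=C(/C=C\Nc1ccc(F)cc1)c1nc(-c2ccc(F)cc2)n2ccccc12` gives > 30000 nM in a functional assay on B16-F10 cells (Mus musculus) for cytotoxicity, read by MTT assay, with a stated time of 48 h (on this read-out higher numbers stand for weaker inhibition and lower numbers for stronger inhibition), a limit of the assay.
Compound 2 `COc1ccc(-c2nc(C(=O)/C=C\Nc3ccc(Cl)cc3)c3ccccn23)cc1` gives 1240 nM in this assay.
Compound 3 `O=C(/C=C\Nc1ccc(F)cc1)c1nc(-c2ccc(C(F)(F)F)cc2)n2ccccc12` gives > 30000 nM in this assay, a limit of the assay.

Compound 3 thus stands at a limit of the assay, one of two such limits among the three values, as the limit of > 30000 nM in this assay, at which 2 of the 3 values shown sit, records. Compound 4 `COc1ccc(-c2nc(C(=O)/C=C\Nc3ccc(F)cc3)c3ccccn23)cc1` differs from it by methoxy in place of trifluoromethyl on an aromatic carbon. Among the compounds with values here, the only step measured in one place, a step that the two limits leave unreadable from compound 1 to compound 3, runs between two limits and its size cannot be read, so it gives no guide. Within the data shown here, compound 2 also carries the methoxy group on the same ring and gives the one numbered value shown. Because compound 2 gives 1240 nM in this assay, compound 4 is expected to be stronger than compound 3, a step of an at least 10-fold lower number from compound 3 to compound 4 (1.00 log units; beyond the scatter). That compound 4 may still fall at a limit of the assay remains possible. The estimate for compound 4 is 3000 nM, between 800 nM and 30000 nM.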

Compound 4, half-maximal inhibitory concentration: > 30000 nM
Compound 4 ended at the assay's limit; the forecaster's own chance of this, stated with the estimate: 25%; middle value at least 10-fold (1.00 log units) from the limit.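

Methoxy in place of trifluoromethyl leaves compound 4 at the limit of this assay, so among these compounds methoxy alone does not yield a numbered value. Fluoro in place of chloro on an aromatic carbon gives an at least 24-fold higher number from compound 2 to compound 4 (1.38 log units; beyond the scatter), which shows that, with methoxy kept, the numbered value of compound 2 goes with its chloro group. The steps among compound 1, compound 3 and compound 4 cannot be read, as all three values are limits: the limit of > 30000 nM in this assay, at which 3 of the 4 values shown sit.

As far as these compounds go, whether chloro would also give a numbered value alongside fluoro or trifluoromethyl in place of methoxy remains open. So does what a bromo or a nitrile group would give in place of chloro.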